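A few compounds are considered here, and "the series" means these few. Any claim that something is new, unique, unknown or untested is made for them only; others in the source may bear on it.

Notes on two measured compounds and one still to be measured, all on the shared core. Compound 1 `O=C(O)c1cc(-c2ccns2)ccc1O` in a functional assay on the whole organism for inhibition, with Rattus norvegicus as the target, read by paw edema (on this read-out higher numbers stand for an effect only at larger amounts of compound and lower numbers for an effect already at smaller amounts), gives 80 mg/kg. Compound 2 `O=C(O)c1cc(-c2ncccn2)ccc1O` in this assay gives 100 mg/kg. Compound 1 holds the lowest of the two numbers, but its gap to compound 2 is within the scatter, so the two stand level on this read-out and no order can be read between them.

Compound 3 `O=C(O)c1cc(-n2cccn2)ccc1O` is not yet measured in this assay. Against compound 1 it shows the change (1H-pyrazol-1-yl in place of 1,2-thiazol-5-yl on an aromatic carbon). Among the compounds with values here, no step between measured compounds is at hand to say what such an exchange does; the only guide is that compound 1 and compound 2, which differ only in the group carried on the shared core, stand within the scatter of each other. On that basis the step in this assay is expected to be small and in neither direction beyond the scatter: a 1.1-fold higher number from compound 1 to compound 3 (0.05 log units; within the scatter). For compound 3 the expected value in this assay is 90 mg/kg, with a range from 45 mg/kg to 180 mg/kg.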

Compound 3, dose for half-maximal effect: 200 mg/kg
For compound 3 the middle estimate is 2.2-fold (0.35 log units) below the measured one; measured number above the stated range.
By their numbers in this assay, from the lowest: compounds 1, 2 and 3 (each within the scatter of the next, the first and the last beyond it).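

At this position, para to a hydroxy group and meta to a carboxy group, the earlier pair left open whether the attached group matters at all; in this assay the exchange of 1,2-thiazol-5-yl for 1H-pyrazol-1-yl now gives a 2.5-fold higher number from compound 1 to compound 3 (0.40 log units; beyond the scatter) and so shows that the position does respond, if only modestly. The two groups match in heavy-atom count, in a five-membered aromatic ring with 2 hetero atoms, in hydrogen-bond donors and acceptors and in carrying no net charge, so these counts do not separate them, and the visible difference in composition is a sulfur exchanged for a second nitrogen. Nothing at hand bears on why the step arises.

Within the data shown here, with compound 2 within the scatter of both compound 1 and compound 3, the series gives only this one step beyond the scatter and no trend across the groups. Still open, as far as these compounds go, is how the read-out responds when this position carries a group of another kind, such as an amine, a carboxylic acid or a longer alkyl chain, and whether a methyl group on the 1H-pyrazol-1-yl ring changes the number.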